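Swapping a Para Group on the Benzyl Ring

This account rests on a few compounds, and the source may have more. Where it says the series, first, only, none or still open, it means among the compounds named here.

This piece follows a single change at the edge of a weak binder. Compound 1 `O=C(N[C@H]1CCN(Cc2ccc(OC(F)(F)F)cc2)C1)c1ccc(-c2cccs2)cc1` was tested in an assay on frontal cortex for displacement of a labelled ligand from Adrenergic receptor alpha-1 (Rattus norvegicus) (on this read-out higher numbers stand for weaker inhibition and lower numbers for stronger inhibition), and gave 16000 nM. That is the highest of the two numbers recorded, meaning the weakest binding among the measured compounds. Among the compounds with values here, the only other measured compound, compound 2 `O=C(N[C@H]1CCN(Cc2ccc(OC(F)(F)F)cc2)C1)c1cccc(-c2cccs2)c1`, gives 1200 nM in this assay, a considerably lower number that lies well beyond the usual scatter; the two differ in where the thiophene is attached to the benzamide, and that difference is not the subject of this step.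

Compound 3 `O=C(N[C@H]1CCN(Cc2ccc(F)cc2)C1)c1ccc(-c2cccs2)cc1` has not been measured. It differs from compound 1 in one place: fluoro in place of trifluoromethoxy on an aromatic carbon. The benzamide side and the pyrrolidine core of compound 1 are carried over unchanged.

Within the data shown here, no measured pair shows what this particular swap does on this assay, so the size of the step can only be guessed. The expectation is a change of about no change at the digits printed from compound 1 to compound 3 (within the scatter), that is, nothing clearly beyond the scatter in either direction. Compound 3 is therefore estimated at 16000 nM, with a range from 5000 nM to 50000 nM.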

Compound 3, inhibition constant: 420 nM
The estimate for compound 3 lay 38-fold (1.58 log units) above the measured number, outside the stated range (below it).
By their numbers in this assay, from the lowest: compound 3; then compound 2; then compound 1.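

Within the data shown here, until now, the only difference among the compounds lay on the benzamide side, so nothing showed whether the group on the benzyl ring mattered. In this assay, fluoro in place of trifluoromethoxy on this aromatic carbon gives a 38-fold lower number from compound 1 to compound 3 (1.58 log units; beyond the scatter), a large step toward stronger inhibition with the benzamide side and the core held fixed, so this position is clearly sensitive to what sits on it. The swap takes away a group of 5 heavy atoms and puts 1 in its place, but no data here explain why the number falls so far.

The compounds shown leave open whether the gain comes from losing trifluoromethoxy or from gaining fluoro specifically, a question that a plain hydrogen, a chlorine, a methoxy group or an amine on the same carbon could help to settle. They also leave open whether the same swap would give a step of similar size with the thiophene attached as in compound 2, since this single pair tests it only on the benzamide of compound 1.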